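From 1H-tetrazol-5-yl to 1,3-thiazol-2-yl on an amide-type nitrogen

This account rests on a few compounds, and the source may have more. Where it says the series, first, only, none or still open, it means among the compounds named here.

- compound 1 `O=C(Nc1nnn[nH]1)c1cc(=O)c2ccccc2o1` gives 0.08 ug/mL
- compound 2 `N#Cc1ccc2oc(C(=O)Nc3nnn[nH]3)cc(=O)c2c1` gives 2.3 ug/mL
- compound 3 `O=C(Nc1nnn[nH]1)c1cc(=O)c2ccc(O)cc2o1` gives 0.11 ug/mL

All three values come from a functional assay on cells (Mast cell, Rattus norvegicus) for inhibition, with a stated time of 15 min (a higher number here means that more compound is needed for the effect, a lower number that less compound is needed), and are read the same way. Among the compounds with values here, compound 1 stands at 0.08 ug/mL and no measured compound lies beyond the scatter on the low side of it. Compound 3 is within the scatter of it, and compound 2 sits well above both.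

Compound 4 `O=C(Nc1nccs1)c1cc(=O)c2ccccc2o1` keeps the core of compound 1 and changes one group 1,3-thiazol-2-yl in place of 1H-tetrazol-5-yl on an amide-type nitrogen so that 1,3-thiazol-2-yl stands in place of 1H-tetrazol-5-yl on an amide-type nitrogen.

Within the data shown here, no measured step touches this group, so the evidence is indirect. Both measured steps are changes on an aromatic carbon of the core. The step of a 29-fold higher number from compound 1 to compound 2 (1.46 log units; beyond the scatter) is large, which shows that one small change can move the number a long way here. The step of a 1.4-fold higher number from compound 1 to compound 3 (0.14 log units; within the scatter) shows that another change can leave it in place. Starting this close to the low end, and with the whole group exchanged, a large move upward in this assay seems the likelier outcome.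

The expected step is a 63-fold higher number from compound 1 to compound 4 (1.80 log units; beyond the scatter) and this estimate is uncertain. For compound 4 the estimated value is 5 ug/mL with an expected range from 0.5 ug/mL to 50 ug/mL as its span.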

Compound 4, concentration for half-maximal effect: > 18 ug/mL
Compound 4 ended at the assay's limit; the forecaster's own chance of this, stated with the estimate: 30%; at least 3.6-fold (0.55 log units) between middle value and limit.
By their numbers in this assay, from the lowest: compounds 1 and 3 (each within the scatter of the next); then compound 2. At a limit, above all of these: compound 4.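

Within the data shown here, until now, the only changes were on an aromatic carbon of the core, so this is the first look at the group on the amide-type nitrogen, and the exchange gives an at least 220-fold higher number from compound 1 to compound 4 (2.35 log units; beyond the scatter). In this assay, compound 4 gives a limit rather than a number: the limit of > 18 ug/mL in this assay, at which 1 of the 4 values shown sits. The leaving and entering groups are both five-membered aromatic rings with the same count of heavy atoms, so keeping that ring size on this nitrogen is not enough to hold the low number of compound 1, although this single exchange cannot say which remaining difference matters, whether the hetero atoms, the sulfur or the missing hydrogen-bond donor.

As far as these compounds go, it remains open whether a carboxylic acid or a 1H-1,2,4-triazol-3-yl group, which sits closer to 1H-tetrazol-5-yl in its nitrogen atoms, would keep the number low at this place. Also open, from the compounds shown here alone, is how far compound 4 lies past its limit, and whether 1,3-thiazol-2-yl would give a similar result on the hydroxy-bearing core of compound 3.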